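The source may hold more compounds than are shown below. What is called first, only, known or untested is meant among the compounds shown, and "the series" means these compounds.

Measured compounds:
compound 1 `O=C(NCc1ccc(CNS(=O)(=O)c2ccccc2F)cc1)c1cc2ccccn2n1` — 100 nM
compound 2 `O=C(NCc1ccc(CNS(=O)(=O)c2ccc3c(c2)CCO3)cc1)c1scc2c1OCCO2` — 10 nM
compound 3 `Cn1nccc1C(=O)NCc1ccc(CNS(=O)(=O)c2ccc3c(c2)CCO3)cc1` — 1000 nM

All three were tested in an assay on cells for displacement of a labelled ligand from C-X-C chemokine receptor type 4 (Homo sapiens), read by fluorescence and microscopy, with stated times of 10 min and 30 min; a higher number here means that more compound is needed for the effect, a lower number that less compound is needed. Among these numbers compound 1 stands second highest: compound 2 gives a lower number at 10 nM, and compound 3 a higher one at 1000 nM, so compound 1 sits between them. Among the compounds with values here, the one step measured between two compounds that differ in a single place is a 100-fold higher number from compound 2 to compound 3 (2.00 log units; beyond the scatter), which concerns the group on the carbonyl carbon, at the far end of the shared core.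

Compound 4 `O=C(NCc1ccc(CNS(=O)(=O)c2cccc(F)c2)cc1)c1cc2ccccn2n1` is the next compound. It is compound 1 with 3-fluorophenyl in place of 2-fluorophenyl on a sulfonyl sulfur. The fluorophenyl group on the sulfonyl sulfur is the same in atoms and changes only in how they are joined. Within the data shown here, no measured step touches this end of the molecule, so nothing in this assay speaks to the change directly, and the large step seen at the carbonyl carbon gives no guide here. The expectation is therefore a step of no change at the digits printed from compound 1 to compound 4 (within the scatter), no change beyond the scatter, with compound 4 estimated at 100 nM, between 30 nM and 300 nM.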

Compound 4, effective concentration (reported as EC, without a stated level of effect): 1000 nM
Beside the measured number, compound 4's estimate is 10-fold (1.00 log units) below it, and the stated range ends below it.
By their numbers in this assay, from the lowest: compound 2; then compound 1; then compounds 3 and 4 (each within the scatter of the next).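

Putting 3-fluorophenyl in place of 2-fluorophenyl on a sulfonyl sulfur gives a 10-fold higher number from compound 1 to compound 4 (1.00 log units; beyond the scatter) in this assay, so more compound is needed for the effect. Within the data shown here, this is the first measured sign that the sulfonyl end of the molecule matters, as the only earlier step concerned the group on the carbonyl carbon. The two groups have the same atoms and the same ring, so a different arrangement of those atoms is enough to produce a step beyond the scatter.

The compounds shown leave open how a plain phenyl, a chlorophenyl or an aminophenyl group on the sulfonyl sulfur would compare, and whether this change gives a step of similar size with another group on the carbonyl carbon. Nothing given here offers an explanation for the step.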